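Propoxy-Linked to Butyl-Linked Tetrazole: Compound 3 to Compound 4

The compounds below may be only part of what the source reports. "The series", "measured", "known", "first", "only" and "open" are said of these compounds alone.

Compound 3 `c1cc(OCCCc2nnn[nH]2)cc(OCc2ccc3ccccc3n2)c1` gives 42 nM in an assay on membranes from lung (Cavia porcellus) for binding affinity to cysteinyl leukotriene receptor (Homo sapiens) (a higher number here means a weaker inhibitor, a lower number a stronger inhibitor), the second highest of the three numbers on hand: compound 2 `CC(CCCC(=O)O)c1cccc(OCc2ccc3ccccc3n2)c1` gives 90 nM, and compound 1 `CCCC(CCc1nnn[nH]1)Cc1cccc(OCc2ccc3ccccc3n2)c1` gives 11 nM. Compound 4 `c1cc(CCCCc2nnn[nH]2)cc(OCc2ccc3ccccc3n2)c1` differs from compound 3 in one place: 4-(1H-tetrazol-5-yl)butyl in place of 3-(1H-tetrazol-5-yl)propoxy on an aromatic carbon. Among the compounds with values here, only one single-site step is known, a 2.1-fold lower number from compound 2 to compound 3 (0.33 log units; beyond the scatter), and it exchanged a carbon-linked acid for an oxygen-linked tetrazole, so it does not test the linker change at hand. Going by these compounds, compound 1 carries its tetrazole on an all-carbon chain and stands lowest, but it also bears an extra chain, so that comparison stays open. The expectation is therefore that compound 4 gives 30 nM (range 10 nM to 90 nM), an expected step of a 1.4-fold lower number from compound 3 to compound 4 (0.15 log units; within the scatter), likely near the scatter.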

Compound 4, inhibition constant: 20 nM
Beside the measured number, compound 4's estimate is 1.5-fold (0.18 log units) above it; measured number inside the range.
By their numbers in this assay, from the lowest: compounds 1 and 4 (each within the scatter of the next); then compound 3; then compound 2.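

In this assay, within the data shown here, 4-(1H-tetrazol-5-yl)butyl in place of 3-(1H-tetrazol-5-yl)propoxy gives a 2.1-fold lower number from compound 3 to compound 4 (0.32 log units; beyond the scatter) as the first single-site comparison of these two chains at this position. Replacing 4-carboxy-1-methylbutyl with the same chain gives a 4.5-fold lower number from compound 2 to compound 4 (0.65 log units; beyond the scatter) on this aromatic carbon, while hydrogen in place of propyl gives a 1.8-fold higher number from compound 1 to compound 4 (0.26 log units; within the scatter) and so leaves no difference beyond the scatter. Nothing available explains the step from compound 3 to compound 4. Going by these compounds, whether a pentyl chain would carry the tetrazole as well as the butyl chain remains open. So does the effect of a thioether link at this position.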